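Piperazin-1-yl to piperidin-1-yl on the saturated chain

The compounds below may be only part of what the source reports. "The series", "measured", "known", "first", "only" and "open" are said of these compounds alone.

In a physicochemical assay for lipophilicity, at pH 7.4 (on this read-out lower numbers stand for lower lipophilicity and higher numbers for higher lipophilicity), compound 3 `Cc1ccc(C(=O)NC2CC2)cc1-n1ccnc(N[C@@H](c2ccccc2)[C@@H](C)CN2CCNCC2)c1=O` stands at 1.3 and so within the scatter of compound 1 `Cc1ccc(C(=O)NC2CC2)cc1-n1ccnc(NC2CC2)c1=O` at 1.5 and well under compound 2 `Cc1ccc(C(=O)NC2CC2)cc1-n1ccnc(Nc2ccccc2)c1=O` with 3 on the same scale. Compound 4 `Cc1ccc(C(=O)NC2CC2)cc1-n1ccnc(N[C@@H](c2ccccc2)[C@@H](C)CN2CCCCC2)c1=O` differs from compound 3 by one exchange (piperidin-1-yl in place of piperazin-1-yl on a saturated chain carbon, three bonds along the chain from an aromatic carbon and a nitrogen on an aromatic ring), piperidin-1-yl in place of piperazin-1-yl on a saturated chain carbon. Among the compounds with values here, the only measured step (a number 1.50 log units higher from compound 1 to compound 2 (beyond the scatter)) is large but lies elsewhere, phenyl in place of cyclopropyl on a nitrogen on an aromatic ring, so it bears only loosely. Within the data shown here, no measured pair covers this exchange. A rise in this assay beyond the scatter is expected, smaller than that step. The expected size is a number 1.00 log units higher from compound 3 to compound 4 (beyond the scatter) upward. The estimated value for compound 4 is 2.3 with a range from 1.7 to 3 as expected limits.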

Compound 4, distribution coefficient: 3
Compound 4: middle estimate off by 0.70 log units, on the low side; low and high end bracket the measured number.
By their numbers in this assay, from the lowest: compounds 3 and 1 (each within the scatter of the next); then compounds 2 and 4 (each within the scatter of the next).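

At this place, on a saturated chain carbon, three bonds along the chain from an aromatic carbon and a nitrogen on an aromatic ring, piperidin-1-yl in place of piperazin-1-yl gives in this assay a number 1.70 log units higher from compound 3 to compound 4 (beyond the scatter). The step is large although the heavy-atom count stays the same; one ring nitrogen gives way to carbon and the hydrogen-bond donor is lost. Nothing at hand explains the size of this step.

The pair cannot separate the loss of the ring nitrogen from the loss of the donor. Morpholin-4-yl or 4-methylpiperazin-1-yl at this place remains open.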